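Imidazolyl thioether to chlorophenyl thioether in compound 1

This account rests on a few compounds, and the source may have more. Where it says the series, first, only, none or still open, it means among the compounds named here.

Compound 1 `O=C(CSc1ncc[nH]1)Nc1ccc2nc(NC(=O)c3ccc(C(F)(F)F)cc3)sc2c1` is the reference point of this pair. Going by the values given here, in a functional assay on U2OS cells (Homo sapiens) for antiproliferative activity, read by MTT assay, with a stated time of 72 h (a lower number here means a stronger inhibitor, a higher number a weaker inhibitor), compound 1 gives 18800 nM, the only numerical reading in the set. Compound 2 `O=C(CSc1nnc(NC(=O)COc2ccccc2)s1)Nc1ccc(Br)cc1` is the other measured member. For compound 2 the reading > 100000 nM is a limit of the assay and not a number, as recorded in the limit of > 100000 nM in this assay, at which 1 of the 2 values shown sits. Among the compounds with values here, compound 2 differs from compound 1 in more than one place, so no measured step links them and only the two readings themselves can be set side by side.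

Compound 3 `O=C(CSc1ccc(Cl)cc1)Nc1ccc2nc(NC(=O)c3ccc(C(F)(F)F)cc3)sc2c1` is the member still to be run. Its difference from compound 1 is 4-chlorophenyl in place of 1H-imidazol-2-yl on a sulfur. Within the data shown here, no measured step covers a change of this kind. The shift from compound 1 to compound 3 in this assay is expected to be small, within or only just beyond the scatter, and its direction cannot be fixed from the readings available. The step expected is a 1.3-fold lower number from compound 1 to compound 3 (0.10 log units; within the scatter). On that basis compound 3 is estimated at 15000 nM, with a range of 4000 nM to 60000 nM.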

Compound 3, half-maximal inhibitory concentration: 2890 nM
Estimate against measurement, compound 3: 5.2-fold (0.72 log units) above; measured number below the stated range.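

In this assay, the group on the sulfur proves to be a place where the reading responds to change: a 6.5-fold lower number from compound 1 to compound 3 (0.81 log units; beyond the scatter). The earlier compounds shown here could not show this, as no measured step touched this sulfur substituent, and the step now shows that the 1H-imidazol-2-yl ring can be replaced by 4-chlorophenyl, a six-membered aromatic ring of carbon only, with the number falling and the rest of the molecule unchanged. This rests on a single pair, and no measured property available here bears on the step.

The compounds shown do not separate a contribution of the chlorine from that of the phenyl ring itself, so unsubstituted phenyl or 4-methoxyphenyl on the same sulfur remains an open comparison. On these data alone, how an amine or a carboxylic acid on that ring would read in this assay is also open, as is the effect of a longer chain in place of the saturated chain carbon on the sulfur.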